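Benzyl phosphate series: adding a nitro group to compound 1

A few compounds are considered here, and "the series" means these few. Any claim that something is new, unique, unknown or untested is made for them only; others in the source may bear on it.

In a physicochemical assay for metabolic stability, at 50 degrees C, tested at 5 uM (on this read-out lower numbers stand for a shorter-lived compound and higher numbers for a longer-lived compound), compound 1 `Nc1ncnc2c1ncn2[C@@H]1O[C@@H]2CO[P@@](=O)(OCc3ccccc3)O[C@H]2[C@H]1O` gives 0.5 h, the middle of the three measured numbers. Compound 3 `Nc1ncnc2c1ncn2[C@@H]1O[C@@H]2CO[P@](=O)(OCc3ccccc3)O[C@H]2[C@H]1O` lies higher at 2.2 h, and compound 2 `Cc1ccc(CO[P@@]2(=O)OC[C@H]3O[C@@H](n4cnc5c(N)ncnc54)[C@H](O)[C@@H]3O2)cc1` lies lower at 0.1 h.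

The next change leads to compound 4 `Nc1ncnc2c1ncn2[C@@H]1O[C@@H]2CO[P@@](=O)(OCc3ccccc3[N+](=O)[O-])O[C@H]2[C@H]1O`: nitro in place of hydrogen on an aromatic carbon. The nitro sits on an aromatic carbon of the benzyl ring, ortho to a large group, and the configuration at phosphorus stays as in compound 1.

Two measured steps are available. The series shows a 4.4-fold higher number from compound 1 to compound 3 (0.64 log units; beyond the scatter), which goes with the fact that compounds 1 and 3 differ only in the configuration as drawn. That step concerns configuration, which does not change here, so it sets no size for this move. The closer precedent is a 22-fold higher number from compound 2 to compound 3 (1.34 log units; beyond the scatter), with hydrogen in place of methyl on an aromatic carbon. It shows that a change on this ring can shift this assay far. However, nitro is a different group from methyl, so that step gives only a loose guide. With compound 2 at 0.1 h on the low side, a rise is tentatively expected, with a wide margin.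

The expected move is a 4.0-fold higher number from compound 1 to compound 4 (0.60 log units; beyond the scatter).

For compound 4, the estimated half-life is 2 h, with an expected range of 0.3 h to 12 h.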

Compound 4, half-life: 83 h
For compound 4 the middle estimate is 42-fold (1.62 log units) below the measured one; the whole stated range lies below it.
By their numbers in this assay, from the lowest: compound 2; then compound 1; then compound 3; then compound 4.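

In this assay the change from benzyl to 2-nitrobenzyl gives a 170-fold higher number from compound 1 to compound 4 (2.22 log units; beyond the scatter), the largest step listed for the series, ahead of a 22-fold higher number from compound 2 to compound 3 (1.34 log units; beyond the scatter) and a 4.4-fold higher number from compound 1 to compound 3 (0.64 log units; beyond the scatter). The earlier compounds showed only that a methyl-bearing ring goes with the lower number in its pair, and the new step adds a case in the opposite direction: the compound carrying the added group, here nitro on an aromatic carbon ortho to a large group, has the higher number, so a substituent on this ring can go with a longer half-life as well as a shorter one, although the two pairs differ in the group, and the methyl pair is drawn with different configurations at phosphorus in the structures shown. No information at hand bears on the cause of this rise.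

The compounds shown leave open whether the rise belongs to nitro itself or would also appear with another group in the same place, such as an amine or a nitrile. They also leave open how nitro behaves with the phosphorus configuration of compound 3, which already stands higher than compound 1 without any group added to the ring.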